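The compounds below may be only part of what the source reports. "The series", "measured", "known", "first", "only" and "open" are said of these compounds alone.

Measured so far:
compound 1 `CNS(=O)(=O)c1ccccc1Nc1cc(-c2ccc3ccn(C)c3c2)c2nccnc2c1` — 2 ug/mL
compound 2 `CN1CCCC(NS(=O)(=O)c2ccccc2Nc2cc(-c3ccc4ccn(C)c4c3)c3nccnc3c2)C1` — 9 ug/mL
compound 3 `Cn1cc(CNS(=O)(=O)c2ccccc2Nc2cc(-c3ccc4ccn(C)c4c3)c3nccnc3c2)cn1` — 2 ug/mL

In a physicochemical assay for solubility, read by spectrophotometry, measured as kinetic solubility, at pH 8, tested at 500 uM (on this read-out lower numbers stand for lower solubility and higher numbers for higher solubility), compound 1 stands level with compound 3 at the digits printed, the two together being the lowest of the three numbers; the furthest is compound 2, with a 4.5-fold higher number from compound 1 to compound 2 (0.65 log units; beyond the scatter). Compound 4 `Cn1ccc2ccc(-c3cc(Nc4ccccc4S(=O)(=O)NCC4CCOCC4)cc4nccnc34)cc21` differs from compound 1 by oxan-4-yl in place of hydrogen on a saturated chain carbon bound to a sulfonamide nitrogen. For the measured compounds named here, two steps bear on this. The closest in kind is the addition of a ring on the same chain carbon, no change at the digits printed from compound 1 to compound 3 (within the scatter). A ring placed directly on the sulfonamide nitrogen gave a 4.5-fold higher number from compound 1 to compound 2 (0.65 log units; beyond the scatter). A step near the scatter, at most a small rise, is therefore expected in this assay, a 1.5-fold higher number from compound 1 to compound 4 (0.18 log units; within the scatter). Compound 4 is estimated at 3 ug/mL, with a range from 1 ug/mL to 9 ug/mL.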

Compound 4, solubility: 2 ug/mL
Compound 4: the middle estimate sits 1.5-fold (0.18 log units) above what was measured, within the range that was stated.
By their numbers in this assay, from the lowest: compounds 1, 3 and 4 (each within the scatter of the next); then compound 2.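

On a saturated chain carbon bound to a sulfonamide nitrogen, oxan-4-yl in place of hydrogen gives no change at the digits printed from compound 1 to compound 4 (within the scatter) in this assay, and oxan-4-yl in place of 1-methyl-1H-pyrazol-4-yl gives no change at the digits printed from compound 3 to compound 4 (within the scatter), so two different rings at this place now read alike. With (oxan-4-yl)methyl in place of 1-methylpiperidin-3-yl on a sulfonamide nitrogen there is a 4.5-fold lower number from compound 2 to compound 4 (0.65 log units; beyond the scatter), which leaves compound 2 alone among the four. No measurement at hand accounts for these readings.

Going by these compounds, a dimethylamino group or a carboxylic acid on the chain carbon remains open. So does whether an oxan-4-yl placed directly on the sulfonamide nitrogen would read like compound 2 or like compound 4.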